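Swapping the triazole substituent on a hydroxylactam core

A few compounds are considered here, and "the series" means these few. Any claim that something is new, unique, unknown or untested is made for them only; others in the source may bear on it.

The study measures compounds in a functional assay on MCF7 cells (Homo sapiens) for antiproliferative activity, read by MTT assay, with a stated time of 24 h; on this read-out higher numbers stand for weaker inhibition and lower numbers for stronger inhibition. Compound 1 `O=C1O/C(=C\Cn2cc(C3=CCCCC3)nn2)C(OCc2ccccc2)=C1OCc1ccccc1`, which carries the cyclohex-1-en-1-yl group on a different core, reaches only the limit of the assay: in this assay compound 1 gives > 100000 nM. Going by the values given here, compound 2 `Cc1ccc(-c2cn(CCC3(O)NC(=O)C(OCc4ccccc4)=C3OCc3ccccc3)nn2)cc1` is the only compound with a number rather than a limit; in this assay compound 2 gives 24000 nM, which marks it as a weak inhibitor. Compound 3 `O=C1NC(O)(CCn2cc(C3=CCCCC3)nn2)C(OCc2ccccc2)=C1OCc1ccccc1` is not yet measured; it differs from compound 2 in one place: cyclohex-1-en-1-yl in place of 4-methylphenyl on an aromatic carbon. Among the compounds with values here, with no measured step between close pairs to lean on, the expected step is a modest loss of potency, possibly one that runs into the limit, and for compound 3 the estimated step is a 2.1-fold higher number from compound 2 to compound 3 (0.32 log units; beyond the scatter). In this assay compound 3 is therefore expected to give about 50000 nM, within a range from 15000 nM to 200000 nM.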

Compound 3, half-maximal inhibitory concentration: > 100000 nM
Compound 3 ended at the assay's limit; the forecaster's own chance of this, stated with the estimate: 40%; middle value at least 2.0-fold (0.30 log units) from the limit.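

In this assay, putting cyclohex-1-en-1-yl in place of 4-methylphenyl on the aromatic carbon of the five-membered ring with 3 nitrogen gives an at least 4.1-fold higher number from compound 2 to compound 3 (0.61 log units; beyond the scatter). Going by these compounds alone, this is the first reading of a single change at this position, and it shows that on this core the measurable activity of compound 2 does not survive the exchange of the aromatic ring for a non-aromatic one. How large the loss really is cannot be told because the read-out of compound 3 stops at a limit: the limit of > 100000 nM in this assay, at which 2 of the 3 values shown sit.

The change removes the methyl group and the aromatic ring together, so the compounds shown do not separate the two. From the compounds shown here alone, whether an unsubstituted phenyl, a saturated cyclohexyl or a 4-methoxyphenyl at this position would give a measurable number remains open.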